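The source may report more compounds than this note shows. Statements on the series, on what has been measured and on what is new or still open speak of the compounds shown alone.

Values so far in a functional assay on T-24 cells (Homo sapiens) for antiproliferative activity, read by MTT assay, with a stated time of 48 h; a higher number here means a weaker inhibitor, a lower number a stronger inhibitor
- Compound 1 `O=C(Nc1cccc(CNc2nccnc2Cl)c1)Nc1ccc(Cl)cc1Cl` gives 5740 nM
- Compound 2 `O=C(Nc1ccc(C(F)(F)F)cc1)Nc1cccc(CNc2nccnc2Cl)c1` gives 4580 nM
- Compound 3 `O=C(Nc1cccc(CNc2nccnc2Cl)c1)NC1CCCCC1` gives > 40000 nM (a limit of the assay, not a number)

Compound 3 has no number of its own, only (the limit of > 40000 nM in this assay, at which 1 of the 3 values shown sits).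

Compound 4 `Cc1ccc(NC(=O)Nc2cccc(CNc3nccnc3Cl)c2)cc1` has 4-methylphenyl in place of cyclohexyl on an amide-type nitrogen.

Among the measured compounds shown here, the one measured step bearing on this is an at least 6.9-fold higher number from compound 1 to compound 3 (0.84 log units; beyond the scatter), with cyclohexyl in place of 2,4-dichlorophenyl at that nitrogen, and the new change runs the opposite way. With compound 1 at 5740 nM and compound 2 at 4580 nM, compound 4 is expected to give a lower number than compound 3 in this assay, beyond the scatter. The expected step is an at least 5.0-fold lower number from compound 3 to compound 4 (0.69 log units; beyond the scatter).

Compound 4 is estimated at 8000 nM, with an expected range from 3500 nM to 22000 nM.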

Compound 4, half-maximal inhibitory concentration: 9820 nM
For compound 4 the middle estimate is 1.2-fold (0.09 log units) below the measured one; the measured number falls inside the stated range.
By their numbers in this assay, from the lowest: compounds 2, 1 and 4 (each within the scatter of the next, the first and the last beyond it). At a limit, above all of these: compound 3.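

In this assay, the aromatic ring on this nitrogen needs no halogen: 4-methylphenyl in place of cyclohexyl gives an at least 4.0-fold lower number from compound 3 to compound 4 (0.60 log units; beyond the scatter). Substituents on that ring matter far less, with 4-methylphenyl in place of 2,4-dichlorophenyl giving a 1.7-fold higher number from compound 1 to compound 4 (0.23 log units; within the scatter) and methyl in place of trifluoromethyl giving a 2.1-fold higher number from compound 2 to compound 4 (0.33 log units; beyond the scatter). Compound 3 has only a limit, not a number, so the size of the aromatic gain stays a bound: the limit of > 40000 nM in this assay, at which 1 of the 4 values shown sits.

Unsubstituted phenyl remains open, as does an amine or a carboxylic acid on that ring. Compound 3 is also the only non-aromatic case, so it is unclear whether a smaller group such as cyclopropyl would behave the same way.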